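Naphthalen-1-yl in place of 4-ethylphenyl: an expected result

The compounds below may be only part of what the source reports. "The series", "measured", "known", "first", "only" and "open" are said of these compounds alone.

Compound 1, `Clc1ccc(-c2cn3ccnc3c(-c3ccc4ncn(C5CCCCC5)c4c3)n2)cc1`, gives 15.8% in a functional assay on SNB-19 cells (Homo sapiens) for inhibition, read by sulforhodamine B assay, with a stated time of 48 h, tested at 10 uM; on this read-out lower numbers stand for less inhibition and higher numbers for more inhibition at the one concentration tested (going by the name of the read-out).
Compound 2, `Fc1ccccc1-c1cn2ccnc2c(-c2ccc3ncn(C4CCCCC4)c3c2)n1`, gives 7.56%.
Compound 3, `CCc1ccc(-c2cn3ccnc3c(-c3ccc4ncn(Cc5ccccc5)c4c3)n2)cc1`, gives 20.9%.

Compound 3 carries the largest of these three numbers. The gap between compound 3 and compound 1 lies within the usual scatter of repeated measurements, and the two cannot be told apart. The gap between compound 3 and compound 2 lies beyond that scatter.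

Compound 4, `c1ccc(Cn2cnc3ccc(-c4nc(-c5cccc6ccccc56)cn5ccnc45)cc32)cc1`, has not yet been measured. It differs from compound 3 in one place: naphthalen-1-yl in place of 4-ethylphenyl on an aromatic carbon.

Among the measured compounds shown here, only one measured step bears on this kind of change. The step of a number 8.2 percentage points lower from compound 1 to compound 2 (within the scatter) swaps one aromatic group for another at the same kind of place and stays within the scatter. Neither 4-ethylphenyl nor naphthalen-1-yl appears in that step, so it offers no direct guide to the new group, and nothing else in the data does.

With so small a precedent, no step beyond the scatter is expected for compound 4; the estimated step is a number 1.9 percentage points lower from compound 3 to compound 4 (within the scatter). Compound 4 is therefore expected to give about 19% in this assay, most likely between 6% and 34%.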

Compound 4, a percentage reported as inhibition, at one concentration (the size of the read-out at that concentration, not a potency): 5.12%
Beside the measured number, compound 4's estimate is 13.9 percentage points above it; the whole stated range lies above it.
By their numbers in this assay, from the lowest: compounds 4, 2, 1 and 3 (each within the scatter of the next, the first and the last beyond it).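

Putting naphthalen-1-yl in place of 4-ethylphenyl on this aromatic carbon, next to the ring nitrogen of the shared core, gives in this assay a number 15.8 percentage points lower from compound 3 to compound 4 (beyond the scatter) and so shows that the aromatic group at this position can shift the read-out by more than ordinary scatter. Among the compounds shown here, the only earlier change at this kind of place, a number 8.2 percentage points lower from compound 1 to compound 2 (within the scatter), could not show that. The swap replaces one six-membered aromatic ring of carbon only with 2 such rings, while neither group has hydrogen-bond donors, hydrogen-bond acceptors or a net charge, but no measurement here explains why the number falls.

These compounds leave open whether the second ring itself matters or how it is attached, a question that naphthalen-2-yl at the same carbon could address. They also leave open whether a phenyl ring carrying an amine or a carboxylic acid would move the read-out at this position, and whether naphthalen-1-yl would have the same effect with a different group elsewhere on the core.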